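The source may report more compounds than this note shows. Statements on the series, on what has been measured and on what is new or still open speak of the compounds shown alone.

Going by the values given here, compound 3 `CS(=O)(=O)c1cc(C(=O)N=C(N)N)ccc1N1CCC(N)CC1` is one of three compounds measured in a functional assay for inhibition of sodium/hydrogen exchanger (Oryctolagus cuniculus); a higher number here means a weaker inhibitor, a lower number a stronger inhibitor; compound 3 gives 160 nM, the second highest of the three numbers. Compound 1 `CS(=O)(=O)c1cc(C(=O)N=C(N)N)ccc1Oc1cccnc1` gives 76 nM and compound 2 `CS(=O)(=O)c1cc(C(=O)N=C(N)N)ccc1Cl` gives 380 nM, so that the number rises a 2.1-fold higher number from compound 1 to compound 3 (0.32 log units; beyond the scatter) and falls a 2.4-fold lower number from compound 2 to compound 3 (0.38 log units; beyond the scatter). Compound 4 `CS(=O)(=O)c1cc(C(=O)N=C(N)N)ccc1-n1ccc(=O)cc1` differs from compound 3 in one place: a group of 7 heavy atoms (5 carbon, 1 nitrogen, 1 oxygen; one six-membered aromatic ring with 1 hetero atom) in place of a group of 7 heavy atoms (5 carbon, 2 nitrogen; one six-membered non-aromatic ring with 1 hetero atom), on an aromatic carbon. Both measured steps at this position were modest, and neither involves the entering group, so the step in this assay from compound 3 to compound 4 is expected to be small in either direction, a 1.1-fold lower number from compound 3 to compound 4 (0.03 log units; within the scatter), with wide uncertainty. Compound 4 is therefore estimated at 150 nM, in a range from 50 nM to 500 nM.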

Compound 4, half-maximal inhibitory concentration: 710 nM
For compound 4 the middle estimate is 4.7-fold (0.68 log units) below the measured one, and the stated range ends below it.
By their numbers in this assay, from the lowest: compound 1; then compound 3; then compounds 2 and 4 (each within the scatter of the next).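

Groups of equal heavy-atom count are not interchangeable at this position in this assay: replacing 4-aminopiperidin-1-yl with the new ring gives a 4.4-fold higher number from compound 3 to compound 4 (0.65 log units; beyond the scatter), and replacing (pyridin-3-yl)oxy with it gives a 9.3-fold higher number from compound 1 to compound 4 (0.97 log units; beyond the scatter), the widest step yet seen here. Against chloro, the same change gives a 1.9-fold higher number from compound 2 to compound 4 (0.27 log units; within the scatter), so compound 2 and compound 4 cannot be told apart.

Nothing available explains these differences. From the compounds shown here alone, it remains open whether plain piperidin-1-yl or phenoxy would fall nearer compound 1 or compound 4.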